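A few compounds are considered here, and "the series" means these few. Any claim that something is new, unique, unknown or untested is made for them only; others in the source may bear on it.

Working notes on the series, followed in an ADME assay on HepG2 cells (Homo sapiens) for cytotoxicity; a higher number here means that more compound is needed for the effect, a lower number that less compound is needed. Compound 1 `Cc1ccc(S(=O)(=O)N[C@@H](CC(=O)NC(C)(C)C)C(=O)NCCNC(=O)Nc2ccccc2)cc1` returns only a limit of the assay, > 11000 nM. Compound 2 `Cc1ccc(S(=O)(=O)N[C@@H](CC(=O)NC(C)(C)C)C(=O)NCCNC(=O)c2cc(Cl)ccc2Cl)cc1` likewise returns only a limit, > 11000 nM. Compound 3 `COc1cc(OC)cc(C(=O)NCCNC(=O)[C@H](CC(=O)NC(C)(C)C)NS(=O)(=O)c2ccc(C)cc2)c1` stands at a limit as well, > 11000 nM. All three values shown thus sit at the same limit (the limit of > 11000 nM in this assay, at which 3 of the 3 values shown sit). The measured steps at the carbonyl carbon, a step that the two limits leave unreadable from compound 1 to compound 2, a step that the two limits leave unreadable from compound 1 to compound 3 and a step that the two limits leave unreadable from compound 2 to compound 3, bear on the change in question, but none of them is readable in size. Compound 4 `C#Cc1cccc(C(=O)NCCNC(=O)[C@H](CC(=O)NC(C)(C)C)NS(=O)(=O)c2ccc(C)cc2)c1` is not yet measured and differs from compound 3 by 3-ethynylphenyl in place of 3,5-dimethoxyphenyl on a carbonyl carbon. With the steps unreadable, no step beyond the scatter is expected, and the value is expected to rest at the limit again. Compound 4 is therefore estimated at 11000 nM, with a range from 6000 nM to 30000 nM. The step this estimate means, a number no higher from compound 3 to compound 4 (the limit leaves the size open), is expected to lie within the scatter.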

Compound 4, half-maximal effective concentration: > 11000 nM
Compound 4 ended at the assay's limit (the forecaster's own chance of this, stated with the estimate: 85%); the middle value sits exactly at the limit.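

In this assay, compound 4 gives only a limit, > 11000 nM, and its steps from compound 1, compound 2 and compound 3 cannot be read: the limit of > 11000 nM in this assay, at which 4 of the 4 values shown sit.

The compounds shown leave open whether the groups on the carbonyl carbon differ at all in this read-out.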